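Swapping the aryl group on an oxazole-type core

The source may report more compounds than this note shows. Statements on the series, on what has been measured and on what is new or still open speak of the compounds shown alone.

Measured so far in an ADME assay on microsomes from liver (Rattus norvegicus) for metabolic stability, read by LC-MS, using NADPH, at 37 degrees C; on this read-out higher numbers stand for a longer-lived compound and lower numbers for a shorter-lived compound:
compound 1 `Cc1oc(-c2ccc(F)cc2)nc1CN1CCC(C(=O)NCCCN2C[C@H](C)C[C@H](C)C2)CC1` gives 0.468 h
compound 2 `Cc1ccccc1-c1nc(CN2CCC(C(=O)NCCCN3CCCC(C(C)C)C3)CC2)c(C)o1` gives 0.323 h
compound 3 `CCCN(CCC)CCNC(=O)C1CCN(Cc2nc(-c3ccccc3C)oc2C)CC1` reaches the limit > 0.5 h, a boundary of this assay rather than a number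

Compound 1 holds the higher of the two plain numbers; compound 2 sits within the scatter of it, so no order between them is claimed. Among the compounds with values here, the one measured step, an at least 1.5-fold higher number from compound 2 to compound 3 (0.18 log units; that floor lies within the scatter), concerns the amine-bearing chain far from the aryl group and does not bear on the change studied here. Compound 4 `Cc1cccc(C)c1-c1nc(CN2CCC(C(=O)NCCCN3C[C@H](C)C[C@H](C)C3)CC2)c(C)o1` differs from compound 1 by 2,6-dimethylphenyl in place of 4-fluorophenyl on an aromatic carbon on the shared core. Within the data shown here, with no step on that position to lean on, the half-life of compound 4 is expected to stay within the scatter of compound 1, a step of a 1.0-fold lower number from compound 1 to compound 4 (0.02 log units; within the scatter), and is estimated at 0.45 h between 0.2 h and 1 h.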

Compound 4, half-life: 0.0517 h
For compound 4 the middle estimate is 8.7-fold (0.94 log units) above the measured one; measured number outside the range, below it.
By their numbers in this assay, from the lowest: compound 4; then compounds 2 and 1 (each within the scatter of the next). At a limit, above all of these: compound 3.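

In this assay, the aryl group on the shared core clearly counts: 2,6-dimethylphenyl in place of 4-fluorophenyl gives a 9.1-fold lower number from compound 1 to compound 4 (0.96 log units; beyond the scatter). This is the only step shown at this position, and it shows that a change here alone can shorten the half-life well beyond the scatter. Nothing shown accounts for the size of this step. Still open, from the compounds shown here alone, is whether losing the fluorine or gaining the two methyl groups carries the step. Plain phenyl, or phenyl with a single methyl group, on the same chain would help separate the two.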